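From compound 2 to compound 3: working notes

This account rests on a few compounds, and the source may have more. Where it says the series, first, only, none or still open, it means among the compounds named here.

Measured so far:
compound 1 `CC1=C(N2CC2)C(=O)C(COc2ccccc2)=C(N2CC2)C1=O`: 5.15
compound 2 `COC(CO)C1=C(N2CC2)C(=O)C(C)=C(N2CC2)C1=O`: 6.9

Of the two numbers in a functional assay on L1210 cells (Mus musculus), with a stated time of 12 days (on this read-out higher numbers stand for higher potency (the scale is a negative logarithm) and lower numbers for lower potency), compound 2 stands highest; compound 1 lies lower by a gap beyond the scatter. The next compound, compound 3 `CC1=C(N2CC2)C(=O)C(Cc2ccccc2)=C(N2CC2)C1=O`, is not yet measured. It differs from compound 2 in one place: benzyl in place of 2-hydroxy-1-methoxyethyl on a double-bonded ring carbon. Within the data shown here, no step between measured compounds is available, so what follows rests on the two values alone. Compound 1 sits well below compound 2, and compound 3, like compound 1, lacks the 2-hydroxy-1-methoxyethyl group that compound 2 carries. A downward step is therefore expected for a number 1.10 log units lower from compound 2 to compound 3 (beyond the scatter), of a size between the scatter and the gap separating compound 1 from compound 2. Compound 3 is estimated at 5.8, within 5 to 6.6.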

Compound 3, logarithm of the reciprocal of the active concentration, log(1/C): 4.85
Compound 3: the middle estimate sits 0.95 log units above what was measured; the measured number lies below the stated range.
By their numbers in this assay, from the lowest: compounds 3 and 1 (each within the scatter of the next); then compound 2.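

At this double-bonded ring carbon, benzyl in place of 2-hydroxy-1-methoxyethyl gives a number 2.05 log units lower from compound 2 to compound 3 (beyond the scatter) in this assay and marks the position as sensitive to the group it carries, a large step for one change. Phenyl in place of phenoxy on the saturated chain carbon gives a number 0.30 log units lower from compound 1 to compound 3 (within the scatter) in the same read-out, so the two aromatic side chains are not told apart here. No measurement in hand bears on the origin of either step.

The change from compound 2 to compound 3 removes the hydroxyl and the methoxy together and adds an aromatic ring, so the part of the side chain tied to the value remains unresolved. As far as these compounds go, whether a 2-hydroxyethyl chain, a 2-methoxyethyl chain or an aminoethyl chain at this carbon would come close to compound 2 at 6.9 stays open.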